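The source may hold more compounds than are shown below. What is called first, only, known or untested is meant among the compounds shown, and "the series" means these compounds.

Measured so far:
compound 1 `CCCS(=O)(=O)Nc1ccc(F)c(C(=O)c2n[nH]c3ncc(-c4cccc(F)c4)cc23)c1F` — an assay for binding affinity to dual specificity mitogen-activated protein kinase kinase 4 (Homo sapiens), read by KINOMEscan, tested at 100 nM; on this read-out higher numbers stand for a weaker effect at the one concentration tested and lower numbers for a stronger effect: 8.2%
compound 2 `CCCS(=O)(=O)Nc1ccc(F)c(C(=O)c2n[nH]c3ncc(-c4ccccc4O)cc23)c1F` — this assay: 9%
compound 3 `CCCS(=O)(=O)Nc1ccc(F)c(C(=O)c2n[nH]c3ncc(-c4cccc(O)c4)cc23)c1F` — this assay: 2.2%

Compound 3 holds the lowest of the three numbers, but the gaps to its neighbours are small: a number 6 percentage points lower from compound 1 to compound 3 (within the scatter) and a number 6.8 percentage points lower from compound 2 to compound 3 (within the scatter), both within the scatter, so the three compounds are not separated by this read-out. The step of a number 0.8 percentage points higher from compound 1 to compound 2 (within the scatter) is likewise within the scatter.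

Compound 4 `CCCS(=O)(=O)Nc1ccc(F)c(C(=O)c2n[nH]c3ncc(-c4ccc(Cl)c(C(F)(F)F)c4)cc23)c1F` differs from compound 3 in one place: 4-chloro-3-(trifluoromethyl)phenyl in place of 3-hydroxyphenyl on an aromatic carbon. Among the compounds with values here, two measured steps touch the same ring. The swap of hydroxy for fluoro, a number 6 percentage points lower from compound 1 to compound 3 (within the scatter), and the shift of hydroxy from one ring position to another, a number 6.8 percentage points lower from compound 2 to compound 3 (within the scatter), both stayed within the scatter. Within the data shown here, no measured step covers a chloro or a trifluoromethyl on this ring, so the expectation rests on the observation that all three substituents tried left the number low. The step of a number 6.8 percentage points higher from compound 3 to compound 4 (within the scatter) is therefore expected to be small, if anything upward, with the wider range reflecting the untested groups. For compound 4 in this assay the estimate is 9%, within 2% to 35%.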

Compound 4, a percentage reported as activity, at one concentration (the size of the read-out at that concentration, not a potency): 15%
Beside the measured number, compound 4's estimate is 6 percentage points below it, within the range that was stated.
By their numbers in this assay, from the lowest: compounds 3, 1, 2 and 4 (each within the scatter of the next, the first and the last beyond it).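

In this assay, this position now shows a step beyond the scatter, though a modest one: a number 12.8 percentage points higher from compound 3 to compound 4 (beyond the scatter), as 4-chloro-3-(trifluoromethyl)phenyl with no hydrogen-bond donor replaces 3-hydroxyphenyl with one. The separation holds only against compound 3, as the other two steps, a number 6 percentage points higher from compound 2 to compound 4 (within the scatter) and a number 6.8 percentage points higher from compound 1 to compound 4 (within the scatter), stay within the scatter. No measured evidence bears on the origin of the step.

Which of the chloro, the trifluoromethyl or the departing hydroxy carries the step remains open, as the change involves all three at once. Also open, from the compounds shown here alone, is how a phenyl ring carrying an amine or a carboxylic acid would read at this position.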